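This account rests on a few compounds, and the source may have more. Where it says the series, first, only, none or still open, it means among the compounds named here.

Measured compounds:
- compound 1, `O=C(c1ccccc1)N(/N=N/c1ccc([N+](=O)[O-])cc1Cl)c1ccc([N+](=O)[O-])cc1Cl`, gives 590 nM in a functional assay on HeLa cells (Homo sapiens) for cytotoxicity, read by MTT assay, with a stated time of 72 h; on this read-out lower numbers stand for stronger inhibition and higher numbers for weaker inhibition
- compound 2, `O=C(c1ccccc1F)N(/N=N/c1ccc([N+](=O)[O-])cc1Cl)c1ccc([N+](=O)[O-])cc1Cl`, gives 2350 nM in this assay
- compound 3, `O=C(c1ccccc1C(F)(F)F)N(/N=N/c1ccc([N+](=O)[O-])cc1Cl)c1ccc([N+](=O)[O-])cc1Cl`, gives 10600 nM in this assay

All three share one core and differ only in the group on the carbonyl carbon. Compound 3 stands at the highest number of the three, that is, the weakest inhibition: an 18-fold higher number from compound 1 to compound 3 (1.25 log units; beyond the scatter), and a 4.5-fold higher number from compound 2 to compound 3 (0.65 log units; beyond the scatter). Compound 4, `O=C(c1ccc(C(F)(F)F)cc1)N(/N=N/c1ccc([N+](=O)[O-])cc1Cl)c1ccc([N+](=O)[O-])cc1Cl`, is built from the same atoms as compound 3, joined differently: 4-(trifluoromethyl)phenyl in place of 2-(trifluoromethyl)phenyl on a carbonyl carbon.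

Among the compounds with values here, no measured step keeps a group and changes where it sits on that ring, so none bears directly on this change. The measured steps show only that putting trifluoromethyl onto an aromatic carbon raised the number a great deal (an 18-fold higher number from compound 1 to compound 3 (1.25 log units; beyond the scatter)), while fluoro raised it less (a 4.0-fold higher number from compound 1 to compound 2 (0.60 log units; beyond the scatter)). Whether trifluoromethyl at a different aromatic carbon gives the same large rise is not told by these data, so the expectation is uncertain and the range is set wide. On balance compound 4 is expected to come out somewhat lower than compound 3, the expected step being a 2.7-fold lower number from compound 3 to compound 4 (0.42 log units; beyond the scatter). For compound 4 the estimate in this assay is 4000 nM, expected to lie between 800 nM and 20000 nM.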

Compound 4, half-maximal inhibitory concentration: 1060 nM
For compound 4 the middle estimate is 3.8-fold (0.58 log units) above the measured one; measured number inside the range.
By their numbers in this assay, from the lowest: compounds 1 and 4 (each within the scatter of the next); then compound 2; then compound 3.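

Keeping the same atoms and only moving the trifluoromethyl group changes the result sharply in this assay, where 4-(trifluoromethyl)phenyl in place of 2-(trifluoromethyl)phenyl on the carbonyl carbon gives a 10-fold lower number from compound 3 to compound 4 (1.00 log units; beyond the scatter), beyond the scatter. The large rise seen earlier therefore does not come with trifluoromethyl wherever it sits on this ring, since the step that adds it as 4-(trifluoromethyl)phenyl to the plain ring of compound 1 gives a 1.8-fold higher number from compound 1 to compound 4 (0.25 log units; within the scatter), which lies within the scatter, while the step from the 2-fluorophenyl group gives a 2.2-fold lower number from compound 2 to compound 4 (0.35 log units; beyond the scatter), which lies beyond it. Nothing measured here explains why the place of the group counts for so much.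

Whether fluoro would follow the same course if it were moved around the ring remains open, as only one place has been shown for it. Also open, as far as these compounds go, is what a different group on this ring, such as an amine, a methoxy group or a carboxylic acid, would do to the number in this assay, at either of the places seen so far.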